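A Side-Chain Swap in a Flat Series

The compounds below may be only part of what the source reports. "The series", "measured", "known", "first", "only" and "open" are said of these compounds alone.

In a functional assay on a cell-free system (plasma, Oryctolagus cuniculus) for inhibition, with stated times of 5 min, 1 min and 6 min (a higher number here means a weaker inhibitor, a lower number a stronger inhibitor), compound 1 `CCOC(=O)c1c(C)nc(-c2cccc(C#N)c2)n1OC` reads 9130 nM while compound 2 `CCOC(=O)c1c(C)nc(-c2cccc(C#N)c2)n1C(C)C` reads 9260 nM and compound 3 `CCOCCOn1c(-c2cccc(C#N)c2)nc(C)c1C(=O)OCC` reads 6250 nM and so stands level with both, within the scatter.

Compound 4 `CCOC(=O)COn1c(-c2cccc(C#N)c2)nc(C)c1C(=O)OCC` differs from compound 3 in one place (ethoxycarbonyl in place of ethoxymethyl on a saturated chain carbon bound to an oxygen on an aromatic ring) with ethoxycarbonyl in place of ethoxymethyl on a saturated chain carbon bound to an oxygen on an aromatic ring. The 2-ethoxyethoxy group thus becomes (ethoxycarbonyl)methoxy.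

For the measured compounds named here, three measured steps bear on this change, since each swaps the group on an aromatic nitrogen. They are a 1.0-fold higher number from compound 1 to compound 2 (0.01 log units; within the scatter) and a 1.5-fold lower number from compound 1 to compound 3 (0.16 log units; within the scatter) and a 1.5-fold lower number from compound 2 to compound 3 (0.17 log units; within the scatter) and all of them stay within the scatter. Going by the values given here, no measured compound has ethoxycarbonyl at this place, so the guess remains uncertain.

With steps this small, no change beyond the scatter is expected in this assay here. The expected size is a 1.1-fold higher number from compound 3 to compound 4 (0.05 log units; within the scatter) according to this estimate. For compound 4 the estimated value is 7000 nM with an expected range from 3000 nM to 16000 nM in this assay.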

Compound 4, half-maximal inhibitory concentration: 6800 nM
Compound 4: middle estimate off by 1.0-fold (0.01 log units), on the high side, within the range that was stated.
By their numbers in this assay, from the lowest: compounds 3, 4, 1 and 2 (each within the scatter of the next).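

Replacing ethoxymethyl with ethoxycarbonyl adds a carbonyl to the side chain, yet in this assay it gives only a 1.1-fold higher number from compound 3 to compound 4 (0.04 log units; within the scatter) and so leaves the reading level. Comparing compound 4 with the other two compounds gives the same picture, with a 1.4-fold lower number from compound 2 to compound 4 (0.13 log units; within the scatter) and a 1.3-fold lower number from compound 1 to compound 4 (0.13 log units; within the scatter), so an ester-bearing chain on the aromatic nitrogen reads level with isopropyl and methoxy in this small set. No measurement available here explains why these compounds read so alike.

Going by these compounds, it remains open whether any group at this position can move the number beyond the scatter. A carboxylic acid in place of ethoxycarbonyl, an amine at the end of the chain, or a longer chain would each test that further.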